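Bromo for chloro on a shared inactive core

A few compounds are considered here, and "the series" means these few. Any claim that something is new, unique, unknown or untested is made for them only; others in the source may bear on it.

The study looks at a single swap of halogen on a shared core. Compound 2 `COc1ccc2[nH]c(=O)c(-c3nc4cc(Cl)ccc4[nH]3)cc2c1` is known only through a limit: in a functional assay on NCI-H460 cells (Homo sapiens) for cytotoxicity, read by MTT assay, with a stated time of 48 h (a lower number here means a stronger inhibitor, a higher number a weaker inhibitor), compound 2 gives > 100000 nM, which is the ceiling of the assay and not a number. Among the compounds with values here, compound 1 `Cc1ccc2[nH]c(=O)c(-c3nc4cc(Br)ccc4[nH]3)cc2c1`, the only other measured member, also reaches only a limit, giving > 100000 nM in this assay. Where compound 2 stands is therefore simple: every value shown for it is a limit, and the one further value shown is a limit as well, so that the limit of > 100000 nM in this assay, at which 2 of the 2 values shown sit, describes the whole picture. The unmeasured compound 3 `COc1ccc2[nH]c(=O)c(-c3nc4cc(Br)ccc4[nH]3)cc2c1` differs from compound 2 by bromo in place of chloro on an aromatic carbon. Within the data shown here, no step between measured compounds is available, and the account does not attach any effect to the change. The expectation is that the step from compound 2 to compound 3 in this assay is none beyond the scatter, the step that the limit leaves unreadable from compound 2 to compound 3 being an estimate only. Compound 3 is therefore expected to give about 150000 nM, within 50000 nM to 500000 nM, most likely reported again as a limit.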

Compound 3, half-maximal inhibitory concentration: > 100000 nM
Compound 3 ended at the assay's limit; the forecaster's own chance of this, stated with the estimate: 85%; the middle value lies beyond the limit too.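

No step can be read from compound 2 or compound 1 to compound 3, as all three compounds stop at the same limit: the limit of > 100000 nM in this assay, at which 3 of the 3 values shown sit.

The compounds shown leave open whether bromo and chloro, or methoxy and methyl, differ at all on the shared core.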